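The source may hold more compounds than are shown below. What is called first, only, known or untested is meant among the compounds shown, and "the series" means these compounds.

Compound 1, `O=c1nc(SCc2ccccc2)ccn1[C@@H]1O[C@H](COP(=O)(O)OP(=O)(O)O)[C@@H](O)[C@H]1O`, is the reference point in this short series. In an in vitro functional assay on 1321-N1 cells for agonist activity at P2Y purinoceptor 6 (Homo sapiens) (a higher number here means that more compound is needed for the effect, a lower number that less compound is needed), compound 1 gives 800 nM, the lowest of the three numbers recorded, and both other compounds lie beyond the usual scatter above it. Compound 2, `Cn1c(=O)ccn([C@@H]2O[C@H](COP(=O)(O)OP(=O)(O)O)[C@@H](O)[C@H]2O)c1=O`, gives 3300 nM in this assay, and compound 3, `N[C@@H]1[C@H](O)[C@@H](COP(=O)(O)OP(=O)(O)O)O[C@H]1n1ccc(=O)[nH]c1=O`, gives 3900 nM. The unmeasured compound 4, `O=C(O)CCSc1ccn([C@@H]2O[C@H](COP(=O)(O)OP(=O)(O)O)[C@@H](O)[C@H]2O)c(=O)n1`, differs from compound 1 in one place: carboxymethyl in place of phenyl on a saturated chain carbon bound to a sulfur. For the measured compounds named here, no measured pair shows this change, so its effect is open. Compound 4 is expected to need somewhat more than compound 1, a step of a 2.5-fold higher number from compound 1 to compound 4 (0.40 log units; beyond the scatter), modest but possibly beyond the scatter. Compound 4 is therefore estimated at 2000 nM, within a range of 600 nM to 6500 nM, pending the measurement.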

Compound 4, half-maximal effective concentration: 1100 nM
Beside the measured number, compound 4's estimate is 1.8-fold (0.26 log units) above it, and the stated range covers the measured number.
By their numbers in this assay, from the lowest: compounds 1 and 4 (each within the scatter of the next); then compounds 2 and 3 (each within the scatter of the next).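

In this assay, carboxymethyl in place of phenyl on a saturated chain carbon bound to a sulfur gives a 1.4-fold higher number from compound 1 to compound 4 (0.14 log units; within the scatter), so the two compounds cannot be told apart. This pair shows that, at this position, benzyl and 2-carboxyethyl can be exchanged without a difference beyond the scatter, and that the six-membered aromatic ring of compound 1 is not required for a number in this range. Nothing available explains this result. The compounds shown leave open how an amine or a methyl ester would compare with the carboxylic acid at the end of this chain. They also leave open what a longer chain would give.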